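A few compounds are considered here, and "the series" means these few. Any claim that something is new, unique, unknown or untested is made for them only; others in the source may bear on it.

Of the compounds shown here, two have been measured in a functional assay on the whole organism (strain Wistar) with Rattus norvegicus as the target, with a stated time of 15 days, at a dose of 30 mg/kg by the oral route; a higher number here means a stronger effect of the compound at the dose given, a lower number a weaker effect. Compound 1, `Cc1nc(COc2ccc(/C=C3\SC(=O)NC3=O)cc2)cs1`, carries the shared core, and in this assay compound 1 gives 26.4%. Compound 2, `O=C1NC(=O)/C(=C/c2ccc(OCCSc3nnc(Cc4ccccc4)[nH]3)cc2)S1`, carries the same core on a chain ending in a five-membered aromatic ring with three nitrogen atoms that bears a benzyl group; in this assay compound 2 gives 38.3%, the higher of the two numbers, and the gap to compound 1 lies beyond the usual scatter of such measurements. Among the compounds with values here, no pair of measured compounds differs in only one place, so nothing measured yet shows how a change on that benzyl-bearing ring moves the number.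

Compound 3, `O=C1NC(=O)/C(=C/c2ccc(OCCSc3nnc(-c4ccc(Cl)cc4)[nH]3)cc2)S1`, has not yet been measured. It differs from compound 2 in one place: 4-chlorophenyl in place of benzyl on an aromatic carbon. The group that leaves and the group that enters hold the same count of heavy atoms and each contains one six-membered aromatic ring of carbon only. Because compound 2 gives 38.3% with this ring arrangement, the expectation for compound 3 rests on that value alone. The expected step is a number 2.3 percentage points lower from compound 2 to compound 3 (within the scatter), that is, no change beyond the scatter. Compound 3 is therefore estimated at 36%, within a range from 20% to 52%.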

Compound 3, a percentage reported as activity, at one dose (the size of the read-out at that dose, not a potency): 32.9%
For compound 3 the middle estimate is 3.1 percentage points above the measured one; the measured number falls inside the stated range.
By their numbers in this assay, from the lowest: compounds 1, 3 and 2 (each within the scatter of the next, the first and the last beyond it).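

At this position, on the aromatic carbon of the five-membered aromatic ring with three nitrogen atoms, putting 4-chlorophenyl in place of benzyl gives a number 5.4 percentage points lower from compound 2 to compound 3 (within the scatter) in this assay. Within the data shown here, this is the first direct reading of a change at this position, and it shows that this swap between two groups of the same heavy-atom count, each with one six-membered aromatic ring of carbon only, does not separate the two compounds at this one dose. Nothing measured here bears on why the number behaves this way.

The swap removes the carbon that links the ring in benzyl and adds a chlorine at the same time, so the compounds shown leave open what each of these two alterations does alone, a question that a plain phenyl group on the same carbon could help to answer. Also open, on these data alone, is whether a group of a different kind at this position, such as an amine or a carboxylic acid, would move the number beyond the scatter.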